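From phenyl to furan-2-yl in a hydroxyphenyl compound

The source may hold more compounds than are shown below. What is called first, only, known or untested is meant among the compounds shown, and "the series" means these compounds.

Values in a functional assay on HeLa cells (Homo sapiens) for cytotoxicity, read by ELISA, with a stated time of 2 days; on this read-out higher numbers stand for weaker inhibition and lower numbers for stronger inhibition:
compound 1 `Oc1cccc(-c2cc(-c3ccccc3)cc(-c3ccccc3)n2)c1`: 16100 nM
compound 2 `Oc1cccc(-c2cc(-c3ccccc3)cc(-c3cccc(O)c3)n2)c1`: 13000 nM
compound 3 `Oc1ccc(-c2cc(-c3ccccc3)cc(-c3ccccc3)n2)cc1`: 1700 nM

Of the three, compound 3 gives the lowest number, 1700 nM. Compound 4 `Oc1ccc(-c2cc(-c3ccccc3)cc(-c3ccco3)n2)cc1` carries furan-2-yl in place of phenyl on an aromatic carbon. Among the measured compounds shown here, no measured step makes this exchange, so the evidence is indirect. The step of a 1.2-fold lower number from compound 1 to compound 2 (0.09 log units; within the scatter) adds hydroxy in place of hydrogen on an aromatic carbon and is small. The larger step of a 9.5-fold lower number from compound 1 to compound 3 (0.98 log units; beyond the scatter) concerns the hydroxyphenyl group, not the group exchanged here. No change beyond the scatter is therefore expected in this assay. The expected step is a 1.2-fold higher number from compound 3 to compound 4 (0.07 log units; within the scatter). Compound 4 is estimated at 2000 nM, with an expected range of 600 nM to 7000 nM.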

Compound 4, half-maximal inhibitory concentration: 10900 nM
The estimate for compound 4 lay 5.5-fold (0.74 log units) below the measured number, outside the stated range (above it).
By their numbers in this assay, from the lowest: compound 3; then compounds 4, 2 and 1 (each within the scatter of the next).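

In this assay, the change at the aromatic carbon next to the ring nitrogen gave a 6.4-fold higher number from compound 3 to compound 4 (0.81 log units; beyond the scatter). This is the first step shown to go beyond the scatter at this position, as the earlier step at the same group, a 1.2-fold lower number from compound 1 to compound 2 (0.09 log units; within the scatter), did not. Phenyl there therefore cannot be exchanged for furan-2-yl without a loss. Nothing available explains this difference between the two rings. From the compounds shown here alone, whether thiophen-2-yl or an amine at this position would match phenyl stays open. So does whether furan-2-yl has the same effect alongside 3-hydroxyphenyl.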